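Closing the amine into a pyrrolidine ring

This account rests on a few compounds, and the source may have more. Where it says the series, first, only, none or still open, it means among the compounds named here.

Compounds measured so far:
- Compound 1, `CN(C)CCC#Cc1cccnc1`: 510 nM
- Compound 2, `CCN(C)CCC#Cc1cccnc1`: 1770 nM

Of the compounds shown here, two have been tested in an assay on brain for binding affinity to Neuronal acetylcholine receptor; alpha4/beta2 (Homo sapiens); on this read-out higher numbers stand for weaker inhibition and lower numbers for stronger inhibition. Compound 1 gives 510 nM, and compound 2, which carries one extra methyl on the amine side chain, gives 1770 nM. Among the measured compounds shown here, of the two numbers, compound 2 stands highest; the only measured step, a 3.5-fold higher number from compound 1 to compound 2 (0.54 log units; beyond the scatter), separates it from compound 1.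

Compound 3, `C(#Cc1cccnc1)CCN1CCCC1`, has not been measured yet. It differs from compound 2 by pyrrolidin-1-yl in place of ethyl(methyl)amino on a saturated chain carbon, two bonds along the chain from a triple-bonded carbon. In plain terms the two open substituents on the amine nitrogen are tied together into a five-membered ring.

For the measured compounds named here, the one step available, a 3.5-fold higher number from compound 1 to compound 2 (0.54 log units; beyond the scatter), shows that adding a single carbon to this amine moved the number upward by a modest amount. Closing the chain into a ring is a different kind of change, so that step can only loosely guide an expectation. For compound 3 in this assay a number somewhat lower than that of compound 2 is expected, a 2.0-fold lower number from compound 2 to compound 3 (0.29 log units; within the scatter), but with wide uncertainty. The estimate for compound 3 is 900 nM, with a range from 250 nM to 3500 nM.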

Compound 3, inhibition constant: > 10000 nM
Compound 3: only a limit was reported; the forecaster's own chance of this, stated with the estimate: 5%; middle value at least 11-fold (1.04 log units) away from the limit.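

In this assay compound 3 gives > 10000 nM, which is a limit of the assay and not a number. Tying the two open amine substituents into pyrrolidin-1-yl proves far from a neutral swap at this position on the saturated chain: the change brings an at least 5.6-fold higher number from compound 2 to compound 3 (0.75 log units; beyond the scatter), and the comparison with the dimethylamino group of the smallest amine here brings an at least 19-fold higher number from compound 1 to compound 3 (1.29 log units; beyond the scatter), which makes this a large step and shows that this end of the molecule can decide whether any binding is seen in this assay at the concentrations reported. On these data alone, the true size of both steps remains unknown because compound 3 sits at a limit rather than at a measured value: the limit of > 10000 nM in this assay, at which 1 of the 3 values shown sits.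

These three compounds cannot separate the effect of having a ring from the effect of simply having more carbon on the amine, since pyrrolidin-1-yl differs from ethyl(methyl)amino in both respects. A smaller ring such as azetidine, a larger one such as piperidine, or the simple methylamino group on the same chain would be needed to tell these two readings apart.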